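The compounds below may be only part of what the source reports. "The series", "measured", "known", "first", "only" and "open" are said of these compounds alone.

Measured so far:
compound 1 `C=C(C)C(=O)N[C@@H](CO)C(=O)O` — 68%
compound 2 `COC(=O)C(=O)N[C@@H](CO)C(=O)O` — "not determined" (no result reported)

In an ADME assay on microsomes from liver (Mus musculus) for metabolic stability, with a stated time of 30 min (a lower number here means that less of the compound is left, a higher number that more of the compound is left), compound 1 gives 68%. For the measured compounds named here, this is the only number at hand; for compound 2 the entry reads "not determined" (no result reported), so compound 1 cannot be placed against any other value. Compound 3 `O=C(CCO)N[C@@H](CO)C(=O)O` has not been measured. It differs from compound 1 in one place: 2-hydroxyethyl in place of 1-methylethenyl on a carbonyl carbon. Going by the values given here, with no measured pair to lean on, the expected step from compound 1 to compound 3 in this assay is a number 8 percentage points higher from compound 1 to compound 3 (within the scatter), a small upward move that may lie within the scatter. Compound 3 is estimated at 76%, with a range from 56% to 92%.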

Compound 3, percent of the compound remaining: 87%
Compound 3: middle estimate off by 11 percentage points, on the low side; measured number inside the range.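

In this assay, placing 2-hydroxyethyl in place of 1-methylethenyl on a carbonyl carbon gives a number 19 percentage points higher from compound 1 to compound 3 (beyond the scatter). This first readable step shows that the group at this place can move the percentage remaining by more than the usual scatter. No available measurement speaks to why the number moved. The oxygen of 2-hydroxyethyl enters as the double bond of 1-methylethenyl leaves, so this single step cannot separate the two changes. From the compounds shown here alone, how an amine, a carboxylic acid or a longer chain would behave at this place remains open.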